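The source may report more compounds than this note shows. Statements on the series, on what has been measured and on what is new or still open speak of the compounds shown alone.

In a functional assay on CHO cells for agonist activity at Alpha-1A adrenergic receptor (Homo sapiens), read by FLIPR and calcium flux (a lower number here means that less compound is needed, a higher number that more compound is needed for the effect), the three measured compounds give:
Compound 1 `c1ccc(-c2cccc3c2CCC3c2ncc[nH]2)nc1` gives 1150 nM.
Compound 2 `CCCS(=O)(=O)Nc1cccc2c1CCC2c1ncc[nH]1` gives 1340 nM.
Compound 3 `CCS(=O)(=O)Nc1cccc(Cc2c[nH]cn2)c1` gives 9 nM.

Among these three numbers compound 1 stands second highest; compound 2 is nearest, at a 1.2-fold higher number from compound 1 to compound 2 (0.07 log units; within the scatter), and compound 3 is furthest, with a far lower number. Among the measured compounds shown here, compound 3 is built on a different core, so its value and that of compound 1 show only that the two compounds are far apart, without telling which part of the structure is responsible.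

Compound 4 `CCS(=O)(=O)Nc1cccc2c1CCC2c1ncc[nH]1` has not yet been measured. Relative to compound 1 the change is (ethylsulfonyl)amino in place of pyridin-2-yl on an aromatic carbon. For the measured compounds named here, the one measured step that bears on this is the exchange of the same pyridin-2-yl for (propylsulfonyl)amino on the same core, which gave a 1.2-fold higher number from compound 1 to compound 2 (0.07 log units; within the scatter), a change within the scatter. Going by the values given here, the (ethylsulfonyl)amino group of compound 4 differs from that propyl group by its chain only, and no measured pair shows what that single difference does on this core. The expectation for compound 4 is therefore a step of a 1.0-fold higher number from compound 1 to compound 4 (0.02 log units; within the scatter), no larger than the scatter, in either direction. The estimated value for compound 4 in this assay is 1200 nM, within a range from 500 nM to 3000 nM.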

Compound 4, half-maximal effective concentration: 32 nM
Beside the measured number, compound 4's estimate is 38-fold (1.57 log units) above it, outside the stated range (below it).
By their numbers in this assay, from the lowest: compound 3; then compound 4; then compounds 1 and 2 (each within the scatter of the next).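

In this assay, the exchange of pyridin-2-yl for (ethylsulfonyl)amino on an aromatic carbon gives a 36-fold lower number from compound 1 to compound 4 (1.56 log units; beyond the scatter), so this position does respond strongly to what is placed on it, which the earlier step between compound 1 and compound 2, within the scatter, did not show. The comparison of the two sulfonyl compounds is sharper still: replacing only a methyl at the end of the propyl chain with hydrogen gives a 42-fold lower number from compound 2 to compound 4 (1.62 log units; beyond the scatter), which means that the end of this chain matters greatly on the shared core, and that the sulfonylamino link alone does not set the result. Nothing available here explains why removing that methyl has so large an effect.

Going by these compounds, with only an ethyl and a propyl chain on the sulfonyl group, it remains open whether a methyl or a butyl chain would continue this direction or reverse it in this assay. On these data alone, it is also open how a plain amine at the same aromatic carbon, without the sulfonyl group, would compare with compound 4.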